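Chloro added to the core of a pyrazole-bearing amide

The compounds below may be only part of what the source reports. "The series", "measured", "known", "first", "only" and "open" are said of these compounds alone.

Of the compounds shown here, two have been measured in an assay on isolated protein for inhibition of thyroid hormone receptor beta (Homo sapiens), read by fluorescence, with a stated time of 30 min; a higher number here means a weaker inhibitor, a lower number a stronger inhibitor. Compound 1 `O=C(NCc1cccc(Cl)c1)c1ccc2cn(CCN3CCOC3=O)nc2c1` carries a 2-oxo-1,3-oxazolidin-3-yl group on the chain from the core nitrogen, and in this assay compound 1 gives 220 nM. Compound 2 `O=C(NCc1cccc(Cl)c1)c1ccc2cn(CCn3cccn3)nc2c1` carries a 1H-pyrazol-1-yl group in its place, and in this assay compound 2 gives 173 nM. Going by the values given here, the only step between them, a 1.3-fold lower number from compound 1 to compound 2 (0.10 log units; within the scatter), lies within the scatter, so compound 2 stands beside compound 1 rather than apart from it.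

Compound 3 `O=C(NCc1cccc(Cl)c1)c1cc(Cl)c2cn(CCn3cccn3)nc2c1` keeps the pyrazole chain and the amide of compound 2 and differs only in the core: chloro in place of hydrogen on an aromatic carbon. Among the compounds with values here, no measured pair in this set changes the core in this way, and the single step from compound 1 to compound 2 concerns the chain substituent, not the core, so it gives no direct guide. With nothing to point either way, the expected step for compound 3 is one that stays within the scatter, a 1.0-fold lower number from compound 2 to compound 3 (0.01 log units; within the scatter). In this assay compound 3 is therefore estimated at 170 nM, with a range from 60 nM to 500 nM.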

Compound 3, half-maximal inhibitory concentration: 225 nM
The estimate for compound 3 lay 1.3-fold (0.12 log units) below the measured number; the range from low to high includes it.
By their numbers in this assay, from the lowest: compounds 2, 1 and 3 (each within the scatter of the next).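

In this assay, chloro in place of hydrogen on this aromatic carbon of the shared core gives a 1.3-fold higher number from compound 2 to compound 3 (0.11 log units; within the scatter). The earlier pair changed only the chain substituent and so said nothing about the core; this step shows that the carbon, ortho to a fused ring and meta to a large group, can carry one added chlorine atom without the number moving beyond the scatter, at least with the 1H-pyrazol-1-yl chain in place. Nothing at hand accounts for this result.

The compounds shown do not tell whether fluoro, methyl, methoxy or an amine on this same carbon would also stay within the scatter of compound 2 or would move the number beyond it. They also leave open whether chloro here would give a similar step with the 2-oxo-1,3-oxazolidin-3-yl chain of compound 1, and whether chloro on another aromatic carbon of the core would do the same.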